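This account rests on a few compounds, and the source may have more. Where it says the series, first, only, none or still open, it means among the compounds named here.

Measured so far:
- compound 1 `COc1cccc(-c2ccc([C@H]3S[C@@H](C)C(=O)Nc4c3c(C)nn4-c3ccccc3C)cc2)c1`: 1800 nM
- compound 2 `Cc1ccccc1-n1nc(C)c2c1NC(=O)[C@H](C)S[C@@H]2c1ccc(/C=C/c2ccccc2)cc1`: "not active" (no number reported)

In an assay on isolated protein for agonist activity at Bile acid receptor (Homo sapiens), read by AlphaScreen, with a stated time of 30 min (on this read-out lower numbers stand for an effect already at smaller amounts and higher numbers for an effect only at larger amounts of compound), compound 1 gives 1800 nM. Compound 2, in contrast, is recorded in this assay only as "not active" (no number reported), so it stands without a single number and cannot be placed on the scale. Compound 3 `COC(=O)c1ccc(-c2ccc([C@H]3S[C@@H](C)C(=O)Nc4c3c(C)nn4-c3ccccc3C)cc2)cc1` is not yet measured in this assay. It differs from compound 2 in one place: 4-(methoxycarbonyl)phenyl in place of 2-phenylethenyl on an aromatic carbon. Among the compounds with values here, with no step between measured compounds recorded, a gain in this assay from compound 2 to compound 3 is expected, since compound 3 carries an aryl group as compound 1 does and that compound gives 1800 nM. Compound 3 is estimated at 2500 nM in this assay, within 600 nM to 10000 nM.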

Compound 3, half-maximal effective concentration: "not active" (no number reported)
The entry for compound 3 holds no number, and the estimate cannot be compared.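

Compound 2 and compound 3 both lack a number in this assay, so no step can be read between them. No evidence bears on this result. The compounds shown leave open which groups at this place, other than that of compound 1 at 1800 nM, give a measurable effect.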